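Replacing hydroxy with nitro in compound 3

The source may hold more compounds than are shown below. What is called first, only, known or untested is meant among the compounds shown, and "the series" means these compounds.

compound 1 `COc1ccc(/C=C\c2cc(OC)c(OC)c(OC)c2)cc1[N+](=O)[O-]` gives 128 nM
compound 2 `COc1ccc(/C=C(/F)c2cc(OC)c(OC)c(OC)c2)cc1N` gives 2.4 nM
compound 3 `COc1ccc(/C(F)=C\c2cc(OC)c(OC)c(OC)c2)cc1O` gives 4 nM

For the measured compounds named here, these three values come from a functional assay on NCI-H460 cells (Homo sapiens) for cytotoxicity, read by sulforhodamine B assay, with a stated time of 72 h (on this read-out higher numbers stand for weaker inhibition and lower numbers for stronger inhibition), and are the only measurements so far. Compound 3 at 4 nM lies within the scatter of compound 2 at 2.4 nM and both sit well under compound 1 at 128 nM on this scale.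

Compound 4 `COc1ccc(/C(F)=C\c2cc(OC)c(OC)c(OC)c2)cc1[N+](=O)[O-]` has not yet been measured. Going by the values given here, it differs from compound 3 by nitro in place of hydroxy on an aromatic carbon, ortho to a methoxy group: nitro in place of hydroxy on an aromatic carbon and no measured pair shows this change alone. Among the compounds with values here, the nearest guide is compound 1, the only measured compound with nitro, which gives 128 nM but carries no fluorine. A higher number, meaning weaker inhibition and a change beyond the scatter, is therefore expected in this assay for this replacement. The expected size is a 15-fold higher number from compound 3 to compound 4 (1.18 log units; beyond the scatter) in this estimate. For compound 4 the estimated value is 60 nM with an expected range from 15 nM to 250 nM in this test.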

Compound 4, half-maximal inhibitory concentration: 379 nM
Estimate against measurement, compound 4: 6.3-fold (0.80 log units) below, and the stated range ends below it.
By their numbers in this assay, from the lowest: compounds 2 and 3 (each within the scatter of the next); then compound 1; then compound 4.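

In this assay, for the compounds shown here, nitro in place of hydroxy on an aromatic carbon, ortho to a methoxy group, gives a 95-fold higher number from compound 3 to compound 4 (1.98 log units; beyond the scatter), the first reading of this change with the rest of the structure held fixed. Before this, nitro was seen only without fluorine, in compound 1 at 128 nM; with fluorine, compound 4 prints the higher number, so carrying fluorine does not bring the nitro compound near the low numbers of compound 3. Nothing measured here accounts for the size of this step.

As far as these compounds go, it remains open how an amine would read on the fluorine arrangement of compound 3, since compound 2 carries its fluorine at the other end of the double bond. From the compounds shown here alone, a nitrile or a carboxylic acid at this position also remains open.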